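The source may report more compounds than this note shows. Statements on the series, on what has been measured and on what is new or still open speak of the compounds shown alone.

In a functional assay on PC-3 cells (Homo sapiens) (on this read-out lower numbers stand for stronger inhibition of growth and higher numbers for weaker inhibition of growth), compound 1 `N#Cc1ccc(/C=C/S(=O)(=O)Cc2ccc(Nc3ncnc4ccccc34)cc2)cc1` reads > 100000 nM, which is a limit of the assay. Within the data shown here, compound 2 `O=S(=O)(/C=C/c1ccc(Cl)cc1Cl)Cc1ccc(Nc2ncnc3ccccc23)cc1` gives 19000 nM, the only actual number so far. Compound 3 `O=S(=O)(/C=C/c1ccc(O)cc1)Cc1ccc(Nc2ncnc3ccccc23)cc1` differs from compound 2 by 4-hydroxyphenyl in place of 2,4-dichlorophenyl on a double-bonded chain carbon bound to a double-bonded chain carbon. Among the measured compounds shown here, the one measured step, an at least 5.2-fold lower number from compound 1 to compound 2 (0.72 log units; beyond the scatter), changes the same place and rests on (the limit of > 100000 nM in this assay, at which 1 of the 2 values shown sits). It is a thin guide, and it suggests that this position can move the read-out towards weaker growth inhibition. The expected change is a modest one, a 1.8-fold higher number from compound 2 to compound 3 (0.27 log units; within the scatter), towards a higher number. Compound 3 is estimated at 35000 nM, with an expected range of 10000 nM to 100000 nM.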

Compound 3, concentration for 50% growth inhibition: 14000 nM
Estimate against measurement, compound 3: 2.5-fold (0.40 log units) above; measured number inside the range.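

In this assay, the step of a 1.4-fold lower number from compound 2 to compound 3 (0.13 log units; within the scatter) lies within the scatter, so 4-hydroxyphenyl and 2,4-dichlorophenyl cannot be told apart at this position, and the chlorines are not required for a reading in this range. The step of an at least 7.1-fold lower number from compound 1 to compound 3 (0.85 log units; beyond the scatter) points the same way as the earlier step from the 4-cyanophenyl compound, so the 4-cyanophenyl group alone stands apart, though this comparison rests on a limit: the limit of > 100000 nM in this assay, at which 1 of the 3 values shown sits.

Open, from the compounds shown here alone, is how an amine, a carboxylic acid or a methoxy group in place of hydroxy would read. Also open, going by these compounds, is whether any group at this position moves the number well beyond the scatter from these two values.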